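The source may hold more compounds than are shown below. What is called first, only, known or untested is meant among the compounds shown, and "the series" means these compounds.

Three compounds share one core and differ only in the aryl group on a carbon with a double bond to nitrogen. Compound 1 `CN(C)CCn1cnnc1-c1cc(Oc2ccc(NC(=O)N/N=C/c3ccc(Cl)cc3Cl)cc2F)ccn1` gives 810 nM in a functional assay on A549 cells (Homo sapiens) for cytotoxicity, read by MTT assay, with a stated time of 72 h; a higher number here means a weaker inhibitor, a lower number a stronger inhibitor. Compound 2 `CN(C)CCn1cnnc1-c1cc(Oc2ccc(NC(=O)N/N=C/c3c[nH]c4ccccc34)cc2F)ccn1` gives 820 nM in this assay, and compound 3 `CN(C)CCn1cnnc1-c1cc(Oc2ccc(NC(=O)N/N=C/c3cc(C(C)(C)C)cc(C(C)(C)C)c3O)cc2F)ccn1` gives 980 nM. Compound 2 thus sits second highest of the three numbers, but all three lie within the usual scatter of one another, so no order among them can be read. Among the compounds with values here, the one measured step at this position, a 1.0-fold higher number from compound 1 to compound 2 (0.01 log units; within the scatter), shows that exchanging one aryl group for a quite different one left the number essentially unchanged.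

Compound 4 `CN(C)CCn1cnnc1-c1cc(Oc2ccc(NC(=O)N/N=C/c3ccc(O)c(Br)c3)cc2F)ccn1` carries the change (3-bromo-4-hydroxyphenyl in place of 1H-indol-3-yl on a carbon with a double bond to nitrogen). Within the data shown here, this is again an exchange of the aryl group at the same place, and the only comparable step, from compound 1 to compound 2, stayed within the scatter, so the step of a 1.0-fold higher number from compound 2 to compound 4 (0.02 log units; within the scatter) is expected to be small as well, in no particular direction. Compound 4 is therefore estimated at 850 nM in this assay, with a range from 400 nM to 1800 nM.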

Compound 4, half-maximal inhibitory concentration: 1370 nM
Beside the measured number, compound 4's estimate is 1.6-fold (0.21 log units) below it; low and high end bracket the measured number.
By their numbers in this assay, from the lowest: compounds 1, 2, 3 and 4 (each within the scatter of the next).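

The exchange gives a 1.7-fold higher number from compound 2 to compound 4 (0.22 log units; within the scatter) and a 1.7-fold higher number from compound 1 to compound 4 (0.23 log units; within the scatter) in this assay, so 3-bromo-4-hydroxyphenyl, which has one aromatic ring and carries both bromine and a hydroxyl group, cannot be told apart from either the two-ring 1H-indol-3-yl or 2,4-dichlorophenyl. The earlier step compared only the last two groups; across compounds 1, 2 and 4, this carbon with a double bond to nitrogen now accepts three quite different aryl groups with no readable difference in the number. No measurement at hand explains these numbers or links them to any property of the groups.

Every group shown at this place is aromatic. On these data alone, whether the number would stay as flat with a saturated ring such as cyclohexyl, or with a phenyl ring carrying a carboxylic acid or an amine, remains open.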